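Changing the ring on the amide nitrogen of compound 2

This account rests on a few compounds, and the source may have more. Where it says the series, first, only, none or still open, it means among the compounds named here.

The measurements come from a functional assay on the whole organism (Ear) for inhibition, with Mus musculus as the target, at a dose of 40 mg/kg by the oral route; a lower number here means less inhibition, a higher number more inhibition at the dose given (going by the name of the read-out). Compound 1 `CNC(=O)c1cc(-c2ccc(F)cc2F)ccc1OC(C)=O` gives 48.8% in this assay. Compound 2 `CC(=O)Oc1ccc(-c2ccc(F)cc2F)cc1C(=O)Nc1cccc(C)c1` gives 12.8% in this assay, the lower of the two numbers at hand, and its nearest neighbour is compound 1. Among the measured compounds shown here, the single measured step, a number 36 percentage points lower from compound 1 to compound 2 (beyond the scatter), goes with 3-methylphenyl in place of methyl on the amide-type nitrogen and is far beyond the scatter.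

Compound 3 `CC(=O)Oc1ccc(-c2ccc(F)cc2F)cc1C(=O)Nc1ccccc1Cl` differs from compound 2 in one place: 2-chlorophenyl in place of 3-methylphenyl on an amide-type nitrogen. For the measured compounds named here, no measured step sets one ring against another on that nitrogen; the only step available exchanges methyl for 3-methylphenyl, and it speaks to compound 3 only in that compound 2 and compound 3 both carry a ring there. The data therefore give no footing for a direction. Compound 3 is expected to stay close to compound 2, with a step of a number 5.2 percentage points higher from compound 2 to compound 3 (within the scatter) that is not expected to lie beyond the scatter. The estimate for compound 3 in this assay is 18%, ranging from 0% to 40%.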

Compound 3, a percentage reported as inhibition, in the whole organism at one dose (the size of the read-out at that dose, not a potency): 41.4%
Estimate against measurement, compound 3: 23.4 percentage points below; measured number above the stated range.
By their numbers in this assay, from the lowest: compound 2; then compounds 3 and 1 (each within the scatter of the next).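

The step (a number 28.6 percentage points higher from compound 2 to compound 3 (beyond the scatter)) shows that in this assay the number depends on which ring sits on the amide-type nitrogen, something the earlier pair could not show, as it set only methyl against 3-methylphenyl. The step (a number 7.4 percentage points lower from compound 1 to compound 3 (within the scatter)) also shows that a ring at this place does not in itself go with a low number: 2-chlorophenyl and methyl cannot be told apart here, so among these three compounds the low number belongs to compound 2 alone and not to the ring-bearing compounds as a group. Nothing at hand offers an explanation for the difference between the two rings.

Since 3-methylphenyl and 2-chlorophenyl differ both in the group the ring carries and in where that group stands, the compounds shown leave open which of the two goes with the step, and 2-methylphenyl or 3-chlorophenyl on the same nitrogen would separate them. Also open, from the compounds shown here alone, is how unsubstituted phenyl or a longer chain such as butyl would fare at this place on the shared core.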